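The compounds below may be only part of what the source reports. "The series", "measured", "known", "first", "only" and "open" are said of these compounds alone.

Measured compounds in a functional assay on brain (Rattus norvegicus, strain Wistar) for inhibition; on this read-out lower numbers stand for stronger inhibition and higher numbers for weaker inhibition:
- compound 1, `CCCCc1ccc(-c2c(C)[nH]c(=O)n2CCCC)cc1`: 12000 nM
- compound 2, `CCCCOc1ccc(-c2c(C)[nH]c(=O)n2C2CCCCC2)cc1`: 13900 nM
- compound 3, `CCCCCCCCCCOc1ccc(-c2c(C)[nH]c(=O)n2C)cc1`: 6900 nM

Compound 2 has the highest of the three numbers shown, but none of the three stands apart: its nearest neighbour is compound 1, and the gap to compound 3, the furthest of the three, also remains within the usual scatter of repeated measurements in this assay. Within the data shown here, on these three numbers, then, no compound can be called stronger or weaker than another; the whole set sits at a similar, weak level of inhibition.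

The next compound, compound 4, `Cc1[nH]c(=O)n(C2CCCCC2)c1-c1ccc(C2CCCCC2)cc1`, differs from compound 2 in one place: cyclohexyl in place of butoxy on an aromatic carbon

Among the measured compounds shown here, no pair among the measured compounds isolates this change, so there is no measured step on which to lean. The three measured compounds differ in several places at once and still fall within the scatter of one another, which suggests that single changes of this kind have so far moved the read-out little. For that reason the expectation for compound 4 is a step from compound 2 of a 1.5-fold lower number from compound 2 to compound 4 (0.19 log units; within the scatter), which is small and not clearly beyond the scatter, leaning if at all toward a somewhat lower number.

Compound 4 is therefore estimated at 9000 nM in this assay, with a range from 3000 nM to 30000 nM.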

Compound 4, half-maximal inhibitory concentration: 28900 nM
Beside the measured number, compound 4's estimate is 3.2-fold (0.51 log units) below it; low and high end bracket the measured number.
By their numbers in this assay, from the lowest: compounds 3, 1 and 2 (each within the scatter of the next); then compound 4.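

In this assay, cyclohexyl in place of butoxy on an aromatic carbon, para to a large group, gives a 2.1-fold higher number from compound 2 to compound 4 (0.32 log units; beyond the scatter), a modest step but the only one in this set that is both isolated to a single place and beyond the scatter. The earlier compounds shown here differed in several places at once and could not show whether this position matters on its own, whereas this pair shows that the read-out does respond to the group held there, with weaker inhibition for the ring than for the open chain. Nothing measured bears on why the number rises, so the step stands as an observation only.

The pair changes several things together, since butoxy carries an oxygen and no ring while cyclohexyl carries a ring and no oxygen, so a pentyl chain or a cyclohexyloxy group at the same place would be needed to separate these two changes. Also open, from the compounds shown here alone, is how an amine or a carboxylic acid at this position would read, and whether the step holds with butyl or methyl in place of the other cyclohexyl on the shared core.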